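Urea aryl swap: tert-butyl to trifluoromethoxy, cytotoxicity outlook

This account rests on a few compounds, and the source may have more. Where it says the series, first, only, none or still open, it means among the compounds named here.

For the measured compounds named here, compound 1 `Cc1cc(NC(=O)Nc2ccc(C(C)(C)C)cc2)c2ccccc2n1` is the one member of this set with an actual number in an ADME assay on BJ cells (Homo sapiens) for cytotoxicity, with a stated time of 72 h (a lower number here means that less compound is needed, a higher number that more compound is needed for the effect), where compound 1 gives 20000 nM. Compound 2 `Cc1cc(NC(=O)Nc2cc(F)cc(F)c2)c2ccccc2n1` reaches only the limit of the assay, > 25000 nM. Compound 3 `Cc1cc(NC(=O)Nc2cccc3nsnc23)c2ccccc2n1` likewise stops at the assay limit, > 25000 nM. Going by the values given here, the set is thus dominated by the limit of > 25000 nM in this assay, at which 2 of the 3 values shown sit, and no step between measured compounds can be drawn. Compound 4 `Cc1cc(NC(=O)Nc2ccc(OC(F)(F)F)cc2)c2ccccc2n1` differs from compound 1 by trifluoromethoxy in place of tert-butyl on an aromatic carbon. Among the compounds with values here, with no measured step to lean on, the expected change in this assay from compound 1 to compound 4 is none beyond the scatter, the estimated step being a 1.1-fold higher number from compound 1 to compound 4 (0.04 log units; within the scatter). Compound 4 is estimated at 22000 nM, within 8000 nM to 60000 nM, with a fair chance that only a limit is reported.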

Compound 4, half-maximal effective concentration: 25000 nM
Beside the measured number, compound 4's estimate is 1.1-fold (0.06 log units) below it; low and high end bracket the measured number.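

In this assay, for the compounds shown here, the swap gives a 1.3-fold higher number from compound 1 to compound 4 (0.10 log units; within the scatter), the first step that can be read. On this aromatic carbon, para to a large group, trifluoromethoxy in place of tert-butyl therefore brings no change beyond the scatter, even though a hydrogen-bond acceptor enters with it. Compound 4 also returns a number rather than a limit.

On these data alone, whether an amine or a carboxylic acid at this position would move the number beyond the scatter remains open. Any upward step would be hard to read in this set: the limit of > 25000 nM in this assay, at which 2 of the 4 values shown sit.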